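A few compounds are considered here, and "the series" means these few. Any claim that something is new, unique, unknown or untested is made for them only; others in the source may bear on it.

Three compounds of this series have a measured number. Compound 1 `Cc1ccc(C(C)C)c(OCCSC(=S)N[C@H]2CCOC2=O)c1` gives 43400 nM in a functional assay on MGC-803 cells (Homo sapiens) for antiproliferative activity, read by MTT assay, with a stated time of 72 h; on this read-out lower numbers stand for stronger inhibition and higher numbers for weaker inhibition. Compound 2 `O=C(COc1ccc(C(=O)/C=C/c2ccccc2Cl)cc1)N[C@H]1CCOC1=O` gives 27100 nM in this assay, and compound 3 `O=C1OCC[C@@H]1NC(=S)SCCOc1ccccc1` gives 53800 nM. Compound 2 thus has the lowest of the three numbers, yet its gaps to compound 1 and to compound 3 both lie within the usual scatter, so the three cannot be told apart. Compound 4 `O=C(COc1ccc(C(=O)/C=C/c2ccc(F)cc2)cc1)N[C@H]1CCOC1=O` is not yet measured; it differs from compound 2 by 4-fluorophenyl in place of 2-chlorophenyl on a double-bonded chain carbon bound to a double-bonded chain carbon. Among the compounds with values here, no measured pair shows this swap, so no step beyond the scatter is expected in this assay in either direction. Compound 4 is therefore estimated at 25000 nM, within 8000 nM to 80000 nM, an expected step of a 1.1-fold lower number from compound 2 to compound 4 (0.04 log units; within the scatter).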

Compound 4, half-maximal inhibitory concentration: > 64000 nM
Compound 4 was reported as a limit; the forecaster's own chance of this, stated with the estimate: 10%; at least 2.5-fold (0.40 log units) between middle value and limit.
By their numbers in this assay, from the lowest: compounds 2, 1 and 3 (each within the scatter of the next). At a limit, above all of these: compound 4.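

The swap of 2-chlorophenyl for 4-fluorophenyl on this double-bonded chain carbon is not neutral in this assay: it gives an at least 2.3-fold higher number from compound 2 to compound 4 (0.37 log units; beyond the scatter). This is the first step shown that lies beyond the scatter, even though both groups count the same heavy atoms. Compound 4 stands only at a limit, so this step gives a minimum size and no exact one: the limit of > 64000 nM in this assay, at which 1 of the 4 values shown sits.

The halogen and where it sits change together, and the compounds shown cannot separate the two. A 4-chlorophenyl or 2-fluorophenyl group at this place would tell them apart.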